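Compound 3 to compound 4: a branched chain end kept

The source may hold more compounds than are shown below. What is called first, only, known or untested is meant among the compounds shown, and "the series" means these compounds.

In a functional assay on ACHN cells (Homo sapiens) for antiproliferative activity, read by sulforhodamine B assay (a higher number here means a weaker inhibitor of growth, a lower number a stronger inhibitor of growth), compound 3 `CC(C)(C)CCOc1cccc(O)c1C(=O)/C=C/c1ccc(O)cc1` gives 3140 nM and lies within the scatter of compound 1 `CC(C)CCCOc1cccc(O)c1C(=O)/C=C/c1ccc(O)cc1` at 3630 nM as one of two numeric values in the set. Compound 2 `CCCCCCOc1cccc(O)c1C(=O)/C=C/c1ccc(O)cc1` is recorded at > 30000 nM which is a limit of the assay. Compound 4 `CC(C)=CCOc1cccc(O)c1C(=O)/C=C/c1ccc(O)cc1` differs from compound 3 by 2-methylprop-1-en-1-yl in place of neopentyl on a saturated chain carbon bound to an oxygen on an aromatic ring and its 3-methylbut-2-en-1-yl chain keeps a branched end. One branched end for another gave a 1.2-fold lower number from compound 1 to compound 3 (0.06 log units; within the scatter) whereas the straight chain of compound 2 stands apart in both an at least 8.2-fold higher number from compound 1 to compound 2 (0.91 log units; beyond the scatter) and an at least 9.5-fold lower number from compound 2 to compound 3 (0.98 log units; beyond the scatter) on the measured steps. The step expected in this assay is a 1.3-fold higher number from compound 3 to compound 4 (0.11 log units; within the scatter) and so none beyond the scatter. For compound 4 the estimated value is 4000 nM with an expected range from 1500 nM to 12000 nM around it.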

Compound 4, concentration for 50% growth inhibition: > 30000 nM
Compound 4: only a limit was reported; the forecaster's own chance of this, stated with the estimate: 10%; middle value at least 7.5-fold (0.87 log units) from the limit.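

In this assay, the 3-methylbut-2-en-1-yl chain gives an at least 9.5-fold higher number from compound 3 to compound 4 (0.98 log units; beyond the scatter) and an at least 8.2-fold higher number from compound 1 to compound 4 (0.91 log units; beyond the scatter), and the value for compound 4 is a limit of the assay. A branched chain end therefore does not by itself keep growth inhibition at this place: compound 1 and compound 3 retain it, while compound 4 goes against that pattern. The step between compound 2 and compound 4 cannot be read, as both are limits: the limit of > 30000 nM in this assay, at which 2 of the 4 values shown sit.

The compounds shown do not separate the double bond from the change in chain length. A saturated 3-methylbutyl chain would address that question.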